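The compounds below may be only part of what the source reports. "The series", "measured", "known", "first", "only" and "open" are said of these compounds alone.

For the measured compounds named here, in a physicochemical assay, with a stated time of 30 min (a higher number here means a weaker inhibitor, a lower number a stronger inhibitor), three compounds built on a shared core have numbers so far. Compound 1 (`COc1cccc(NC(=O)C2Cc3cc(OC)c(OC)cc3C2=O)c1`) gives 38.9 ug/mL, compound 2 (`COc1cc2c(cc1OC)C(=O)C(C(=O)Nc1cccc(Cl)c1)C2`) gives 76.3 ug/mL, and compound 3 (`CCOc1ccccc1NC(=O)C1Cc2cc(OC)c(OC)cc2C1=O`) gives 63.7 ug/mL. Compound 3 lies within the scatter of both others, so these numbers do not rank the three compounds. Compound 4 (`COc1cc2c(cc1OC)C(=O)C(C(=O)Nc1ccccc1Br)C2`) differs from compound 3 in one place: bromo in place of ethoxy on an aromatic carbon. In words, this is bromo in place of ethoxy on an aromatic carbon, ortho to a large group. Going by the values given here, only one measured step offers a comparison, chloro in place of methoxy on an aromatic carbon, which is a 2.0-fold higher number from compound 1 to compound 2 (0.29 log units; within the scatter). That step also replaces an ether group with a halogen, though with different groups and not at the same place, and it stays within the scatter. No step beyond the scatter is therefore expected in this assay. The estimated step is a 1.0-fold higher number from compound 3 to compound 4 (0.01 log units; within the scatter). The expected value for compound 4 is 65 ug/mL, with an estimated range of 32 ug/mL to 130 ug/mL.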

Compound 4, half-maximal inhibitory concentration: 65.4 ug/mL
Compound 4: middle estimate off by 1.0-fold (0.00 log units), on the low side; low and high end bracket the measured number.
By their numbers in this assay, from the lowest: compounds 1, 3, 4 and 2 (each within the scatter of the next).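

In this assay, bromo in place of ethoxy on an aromatic carbon, ortho to a large group, gives a 1.0-fold higher number from compound 3 to compound 4 (0.01 log units; within the scatter), so at this position a single bromine atom stands in for the three heavy atoms of ethoxy without a step beyond the scatter. The earlier compounds shown here had offered only chloro in place of methoxy, and compound 4 now extends the ether-to-halogen comparison to this position. The wider changes at the amide-type nitrogen also stay within the scatter: 2-bromophenyl in place of 3-chlorophenyl gives a 1.2-fold lower number from compound 2 to compound 4 (0.07 log units; within the scatter), and 2-bromophenyl in place of 3-methoxyphenyl gives a 1.7-fold higher number from compound 1 to compound 4 (0.23 log units; within the scatter).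

Going by these compounds, how an amine or a carboxylic acid on this aromatic carbon would read in this assay remains open. Nothing available accounts for how close these numbers lie.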